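This account rests on a few compounds, and the source may have more. Where it says the series, first, only, none or still open, it means among the compounds named here.

Measured compounds and their values:
compound 1 `Cc1nc(-c2cccc(NC(=O)C3CCCN(C(=O)c4cc(C(F)(F)F)cc(C(F)(F)F)c4)C3)c2)cs1` gives 1% in an ADME assay on PC-3 cells (Homo sapiens) for cytotoxicity, read by WST assay, tested at 100 uM; a higher number here means more inhibition at the concentration tested (going by the name of the read-out), a lower number less inhibition;
compound 2 `O=C(Nc1ccc(Cl)cc1)C1CCCN(C(=O)c2cccc(-c3cccs3)c2)C1` gives 4% in this assay;
compound 3 `O=C(Nc1cccc(CN2CCCC2)c1)C1CCCN(C(=O)c2cc(C(F)(F)F)cc(C(F)(F)F)c2)C1` gives 51% in this assay.

Compound 2 stands second highest of the three numbers in this assay. Its nearest neighbour is compound 1, whose value lies within the scatter of that of compound 2, so no order between the two can be read. The furthest is compound 3, whose value lies well beyond the scatter above that of compound 2.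

Compound 4 `CC(=O)Nc1cccc(C(=O)N2CCCC(C(=O)Nc3ccc(Cl)cc3)C2)c1` is not yet measured. It differs from compound 2 in one place: acetamido in place of thiophen-2-yl on an aromatic carbon. Among the measured compounds shown here, the only step so far, a number 50 percentage points higher from compound 1 to compound 3 (beyond the scatter), is large, but it concerns a different part of the shared core and a different pair of groups, so it does not bear on the present change. For the measured compounds named here, the thiophen-2-yl to acetamido exchange has no measured counterpart. With compound 2 and compound 1 both low in this assay, compound 4 is expected to stay near compound 2, with the step from compound 2 to compound 4 estimated as a number 4 percentage points higher from compound 2 to compound 4 (within the scatter), within the scatter. The estimated value of compound 4 in this assay is 8%, with a range from 0% to 30%.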

Compound 4, a percentage reported as inhibition, at one concentration (the size of the read-out at that concentration, not a potency): 4%
For compound 4 the middle estimate is 4 percentage points above the measured one, within the range that was stated.
By their numbers in this assay, from the lowest: compounds 1, 2 and 4 (each within the scatter of the next); then compound 3.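

In this assay, the exchange on an aromatic carbon, meta to a large group, gives no change at the digits printed from compound 2 to compound 4 (within the scatter) for acetamido in place of thiophen-2-yl. Among the compounds shown here, this is the first reading at this position: a five-membered aromatic ring with one hetero atom gives way to a group with no ring and one hydrogen-bond donor, and the two numbers cannot be told apart. Nothing measured on these compounds accounts for this result.

Going by these compounds, both groups carry no net charge, so what an amine or a carboxylic acid at this position would give stays open. Also open, on these data alone, is whether a longer chain in place of the acetamido methyl would read the same in this assay on this core.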